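The compounds below may be only part of what the source reports. "The series", "measured", "known", "first", "only" and "open" are said of these compounds alone.

Measured so far:
- Compound 1, `Cc1ccccc1-c1nn(-c2ccc(C(F)(F)F)cc2)cc1CNCCN1CCN(C)CC1` — 11000 nM in an ADME assay on Huh-7 cells (Homo sapiens) for cytotoxicity; a lower number here means that less compound is tolerated, a higher number that more compound is tolerated
- Compound 2, `CN1CCN(CCNCc2cn(-c3ccc(C(F)(F)F)cc3)nc2-c2ccc(Cl)cc2)CC1` — 3000 nM
- Compound 3, `CN1CCN(CCNCc2cn(-c3ccc(C(F)(F)F)cc3)nc2-c2ccc(OC(F)(F)F)cc2)CC1` — 3000 nM

Compound 1 gives the highest of the three numbers, so it is the best tolerated compound measured here; the step to compound 2 is a 3.7-fold lower number from compound 1 to compound 2 (0.56 log units; beyond the scatter) and to compound 3 is a 3.7-fold lower number from compound 1 to compound 3 (0.56 log units; beyond the scatter), while compound 2 to compound 3 shows no change at the digits printed from compound 2 to compound 3 (within the scatter). Compound 4, `Cc1ccccc1-c1nn(Cc2ccccc2)cc1CNCCN1CCN(C)CC1`, differs from compound 1 in one place: benzyl in place of 4-(trifluoromethyl)phenyl on an aromatic nitrogen. Among the compounds with values here, none of the measured steps touches this group on the aromatic nitrogen of the five-membered aromatic ring with 2 nitrogen; all three vary the 2-methylphenyl group instead. Within the data shown here, no measured step therefore bears on this change, and no step beyond the scatter is expected, a 1.1-fold higher number from compound 1 to compound 4 (0.04 log units; within the scatter). Compound 4 is estimated at 12000 nM, from 5000 nM to 30000 nM.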

Compound 4, half-maximal cytotoxic concentration: > 20000 nM
Compound 4 was reported as a limit; the forecaster's own chance of this, stated with the estimate: 15%; at least 1.6-fold (0.22 log units) between middle value and limit.
By their numbers in this assay, from the lowest: compounds 2 and 3 (each within the scatter of the next); then compound 1. At a limit, above all of these: compound 4.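

This is the first change shown on the aromatic nitrogen, and in this assay benzyl in place of 4-(trifluoromethyl)phenyl gives an at least 1.8-fold higher number from compound 1 to compound 4 (0.25 log units; that floor lies within the scatter). The result for compound 4 is a limit, not a number: the limit of > 20000 nM in this assay, at which 1 of the 4 values shown sits. The number does not fall with this change, but the floor of the step alone does not separate compound 4 from compound 1.

From the compounds shown here alone, it remains open whether a plain phenyl or a longer chain such as phenethyl on this nitrogen would shift the number the same way. Going by these compounds, it is also open whether benzyl would do so alongside the 4-chlorophenyl group of compound 2.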